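This account rests on a few compounds, and the source may have more. Where it says the series, first, only, none or still open, it means among the compounds named here.

Measured in an ADME assay on the whole organism (strain Sprague-Dawley) for pharmacokinetics, with Rattus norvegicus as the target, read by LC-MS, at a dose of 50 mg/kg by the oral route; on this read-out lower numbers stand for lower exposure and higher numbers for higher exposure at the dose given:
- compound 1 `CCC(CC)O[C@@H]1C=C(C(=O)O)C[C@H](NC(C)=N)[C@H]1NC(C)=O`: 1840 nM
- compound 2 `CCOC(=O)C1=C[C@@H](OC(CC)CC)[C@H](NC(C)=O)[C@@H](N/C(C)=N/O)C1`: 8390 nM
- compound 3 `CCOC(=O)C1=C[C@@H](OC(CC)CC)[C@H](NC(C)=O)[C@@H](N/C(N)=N\O)C1`: 270 nM

Of these three, compound 3 stands lowest, at 270 nM. The next structure, compound 4 `CCOC(=O)C1=C[C@@H](OC(CC)CC)[C@H](NC(C)=O)[C@@H](NC(C)=N)C1`, differs from it by one change: a group of 3 heavy atoms (2 carbon, 1 nitrogen; no ring) in place of a group of 4 heavy atoms (1 carbon, 2 nitrogen, 1 oxygen; no ring), on an amine nitrogen. For the measured compounds named here, the only measured step that bears on this directly also changed the group on that amine nitrogen, and it was large: a 31-fold lower number from compound 2 to compound 3 (1.49 log units; beyond the scatter). Compound 1 carries the entering group on the same nitrogen and gives 1840 nM, although it differs from compound 4 elsewhere. So in this assay a clear rise beyond the scatter is expected, somewhat smaller than that drop: a 9.3-fold higher number from compound 3 to compound 4 (0.97 log units; beyond the scatter). Compound 4 is estimated at 2500 nM, with an expected range of 600 nM to 9000 nM.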

Compound 4, maximal plasma concentration: 566 nM
Estimate against measurement, compound 4: 4.4-fold (0.65 log units) above, and the stated range ends above it.
By their numbers in this assay, from the lowest: compound 3; then compound 4; then compound 1; then compound 2.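

In this assay, the group on the amine nitrogen matters in both directions: a 2.1-fold higher number from compound 3 to compound 4 (0.32 log units; beyond the scatter) is a modest step, whereas a 15-fold lower number from compound 2 to compound 4 (1.17 log units; beyond the scatter) is a large one, leaving the group of compound 2 clearly the best of the three. With that nitrogen group held fixed, ethyl in place of hydrogen on an oxygen next to a carbonyl group gives a 3.3-fold lower number from compound 1 to compound 4 (0.51 log units; beyond the scatter) and so does not raise the number here. No measurement here explains either shift. On these data alone, whether the ethyl change would act the same way with the groups of compound 2 or compound 3 remains open. So does the effect of a longer chain on that nitrogen.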